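Cytotoxicity notes: from compound 2 to compound 3

The source may report more compounds than this note shows. Statements on the series, on what has been measured and on what is new or still open speak of the compounds shown alone.

Measured so far:
- compound 1 `COc1ccc(C2=C(c3cc(OC)c(OC)c(OC)c3)C(=O)C(OC(C)=O)C2)cc1OC(C)C`: > 100 ug/mL
- compound 2 `COc1ccc(OC)c(C2=C(c3cc(OC)c(OC)c(OC)c3)C(=O)CC2O[SiH2]C(C)(C)C)c1`: 100 ug/mL

Going by the values given here, in an ADME assay on L132 cells (Homo sapiens) for cytotoxicity, read by MTT assay, with a stated time of 72 h (a lower number here means a stronger inhibitor, a higher number a weaker inhibitor), compound 2 gives 100 ug/mL, and this is the only actual number so far. Compound 1 reads > 100 ug/mL, which is a limit of the assay and not a number.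

The next compound to be read is compound 3 `COc1ccc(C2=C(c3cc(OC)c(OC)c(OC)c3)C(=O)CC2O[SiH2]C(C)(C)C)cc1OC`. It has the same atoms as compound 2, joined differently: 3,4-dimethoxyphenyl in place of 2,5-dimethoxyphenyl on a double-bonded ring carbon. In words, 3,4-dimethoxyphenyl stands in place of 2,5-dimethoxyphenyl on a double-bonded ring carbon, and the rest of the molecule is unchanged.

Among the compounds with values here, no pair of measured compounds shows what a change of this kind does in this assay, so the expectation has only one anchor: compound 2 at 100 ug/mL. No direction can be argued from the data, and no shift beyond the usual scatter is expected. The expected move is a 1.3-fold lower number from compound 2 to compound 3 (0.10 log units; within the scatter). A result reported only as a limit would not be surprising. The estimate for compound 3 is 80 ug/mL, with an expected range from 30 ug/mL to 150 ug/mL.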

Compound 3, half-maximal inhibitory concentration: > 100 ug/mL
Compound 3 was reported as a limit; the forecaster's own chance of this, stated with the estimate: 40%; middle value at least 1.2-fold (0.09 log units) away from the limit.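

In this assay compound 3 reads > 100 ug/mL as a limit of the assay and not a number. Going by these compounds alone, this gives the first step at this position, a number no lower from compound 2 to compound 3 (the limit leaves the size open) with 3,4-dimethoxyphenyl in place of 2,5-dimethoxyphenyl on a double-bonded ring carbon, so moving the two methoxy groups around the aryl ring brings no lower number here. The size of the step stays unreadable because of where the new value sits: the limit of > 100 ug/mL in this assay, at which 2 of the 3 values shown sit.

The compounds shown leave open whether any group on this aryl ring, such as an amine or a carboxylic acid in place of a methoxy group, would bring the number clearly lower in this assay. Within the data shown here, with only one actual number, they also leave open how far the 2,5-dimethoxyphenyl and 3,4-dimethoxyphenyl compounds really lie apart.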